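This account rests on a few compounds, and the source may have more. Where it says the series, first, only, none or still open, it means among the compounds named here.

Of the compounds shown here, two that share a core have been tested in an assay on HEK293 cells for inhibition of Steryl-sulfatase (Homo sapiens), tested at 0.1 uM; on this read-out lower numbers stand for a weaker effect and higher numbers for a stronger effect at the one concentration tested. Compound 1 `CCN(Cc1cccnc1)c1ccc(C(=O)N2CCc3ccc(OS(N)(=O)=O)cc3C2)cc1` is the one with the higher of the two numbers: in this assay compound 1 gives 35.7%, while compound 2 `CCN(Cc1ccccc1)Cc1ccc(S(=O)(=O)N2CCc3ccc(OS(N)(=O)=O)cc3C2)cc1` gives 10%, a gap that lies beyond the usual scatter. Compound 2 differs from compound 1 in more than one place, so nothing can be said about which part of it accounts for the gap.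

Compound 3 `CCCN(Cc1ccccc1)c1ccc(C(=O)N2CCc3ccc(OS(N)(=O)=O)cc3C2)cc1` has not yet been measured. It differs from compound 1 in one place: benzyl(propyl)amino in place of ethyl((pyridin-3-yl)methyl)amino on an aromatic carbon. Among the measured compounds shown here, no step of exactly this kind has been measured among the two known compounds, so the expectation rests on compound 1 alone. Compound 3 is expected to give 32% in this assay, within a range from 12% to 55%, because compound 1 gives 35.7% and the expected step of a number 3.7 percentage points lower from compound 1 to compound 3 (within the scatter) is small, with no clear direction beyond the scatter.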

Compound 3, a percentage reported as inhibition, at one concentration (the size of the read-out at that concentration, not a potency): 64.8%
Estimate against measurement, compound 3: 32.8 percentage points below, and the stated range ends below it.
By their numbers in this assay, from the lowest: compound 2; then compound 1; then compound 3.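

Replacing ethyl((pyridin-3-yl)methyl)amino with benzyl(propyl)amino on this aromatic carbon, para to a large group, gives a step of a number 29.1 percentage points higher from compound 1 to compound 3 (beyond the scatter) in this assay. This shows that the read-out responds to the group at this position, and that a ring with a hetero atom is not needed here for a higher number. The change alters two things at once, the ring and the chain on the nitrogen, and no measurement available here bears on the reason for the step.

From the compounds shown here alone, it remains open whether the higher number belongs to the carbon-only ring or to the propyl chain, and benzyl(ethyl)amino at this place would separate the two. Going by these compounds, whether a longer chain, such as butyl in place of propyl, would raise the number further is also open.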